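Amino for Nitro in a Styryl Sulfonamide Pair

A few compounds are considered here, and "the series" means these few. Any claim that something is new, unique, unknown or untested is made for them only; others in the source may bear on it.

Compound 1, `COc1ccc(/C=C/S(=O)(=O)Nc2c(F)c(F)c(F)c(F)c2F)cc1[N+](=O)[O-]`: 75000 nM in a functional assay on K562 cells (Homo sapiens) for cytotoxicity, read by trypan blue exclusion, with a stated time of 96 h; a higher number here means a weaker inhibitor, a lower number a stronger inhibitor.
Compound 2, `COc1ccc(/C=C/S(=O)(=O)Nc2c(F)c(F)c(F)c(F)c2F)cc1N`: 35000 nM in this assay.
Compound 3, `COc1cc(OC)c(/C=C/S(=O)(=O)Nc2ccc(OC)c([N+](=O)[O-])c2)c(OC)c1`: 1000 nM in this assay.

Compounds 1 and 2 share one core and differ by a single change: amino in place of nitro on an aromatic carbon. That change gave a 2.1-fold lower number from compound 1 to compound 2 (0.33 log units; beyond the scatter) in this assay.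

Compound 3 stands apart. It has the lowest number of the three, with compound 2 nearest and compound 1 furthest from it. How its core differs from the core of compound 1 is not broken down here.

Compound 4, `COc1cc(OC)c(/C=C/S(=O)(=O)Nc2ccc(OC)c(N)c2)c(OC)c1`, has not yet been measured. It stands to compound 3 as compound 2 stands to compound 1: amino in place of nitro on an aromatic carbon. The surroundings of the change are the same in both pairs, so this is the same change made on a different core.

Among the compounds with values here, on that basis the step from compound 3 to compound 4 is expected to resemble the one from compound 1 to compound 2, namely a 2.0-fold lower number from compound 3 to compound 4 (0.30 log units; within the scatter) in this assay, because a 2.1-fold lower number from compound 1 to compound 2 (0.33 log units; beyond the scatter) is the only measured precedent. Compound 4 is therefore estimated at 500 nM, with a likely range from 250 nM to 1500 nM in this assay.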

Compound 4, half-maximal inhibitory concentration: 3 nM
Estimate against measurement, compound 4: 170-fold (2.22 log units) above; the measured number lies below the stated range.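

On the core of compound 3, the change gave a 330-fold lower number from compound 3 to compound 4 (2.52 log units; beyond the scatter) in this assay, so the direction seen on the core of compound 1 held, but the size did not. The two steps differ by more than repeated measurements would account for: the same change on two cores in this assay, a 2.1-fold lower number (0.33 log units; beyond the scatter) from compound 1 to compound 2 and a 330-fold lower number (2.52 log units; beyond the scatter) from compound 3 to compound 4, 160-fold (2.19 log units) apart, beyond the scatter of two such steps

Amino for nitro therefore cannot be carried between these two cores as a fixed increment, although two pairs cannot show which difference between the cores goes with the larger step, nor how the change would behave on a third core.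

The compounds shown leave open whether an acetamide or a dimethylamino group in place of the amino group on the core of compound 4 would keep a number as low as that of compound 4. They also leave open whether the large step would survive if only the methoxy groups or only the fluorine atoms of the two cores were exchanged.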